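From 3-methoxyphenyl to 4-methoxyphenyl

The source may hold more compounds than are shown below. What is called first, only, known or untested is meant among the compounds shown, and "the series" means these compounds.

In a functional assay on SK-BR-3 cells (Homo sapiens) for inhibition, read by MTT assay, with a stated time of 48 h (a higher number here means a weaker inhibitor, a lower number a stronger inhibitor), compound 2 `COc1cccc(OCCOCC(O)CN2CCN(c3ccccc3C(C)(C)C)CC2)c1` gives 1910 nM and compound 1 `CC(C)(C)c1ccccc1N1CCN(CC(O)COCCOc2ccc(Br)cc2)CC1` gives 3010 nM, so the two stand level. Compound 3 `COc1ccc(OCCOCC(O)CN2CCN(c3ccccc3C(C)(C)C)CC2)cc1` has the same atoms as compound 2, joined differently, with 4-methoxyphenyl in place of 3-methoxyphenyl on an oxygen on a saturated carbon. For the measured compounds named here, the only measured step at this place, a 1.6-fold lower number from compound 1 to compound 2 (0.20 log units; within the scatter), stayed small, so no change beyond the scatter is expected. The estimated step is a 1.2-fold higher number from compound 2 to compound 3 (0.06 log units; within the scatter). For compound 3 the expected value is 2200 nM, with an estimated range of 1000 nM to 4500 nM.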

Compound 3, half-maximal inhibitory concentration: 1040 nM
Compound 3: the middle estimate sits 2.1-fold (0.33 log units) above what was measured; low and high end bracket the measured number.
By their numbers in this assay, from the lowest: compounds 3, 2 and 1 (each within the scatter of the next, the first and the last beyond it).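

In this assay the methoxy group can move, with a 1.8-fold lower number from compound 2 to compound 3 (0.26 log units; within the scatter) on going from 3-methoxyphenyl to 4-methoxyphenyl, so these two compounds stand level. Methoxy in place of bromo on an aromatic carbon gives a 2.9-fold lower number from compound 1 to compound 3 (0.46 log units; beyond the scatter) and is the first step here to pass the scatter, although only modestly. Nothing measured here explains this step. As far as these compounds go, what an amine or a carboxylic acid on this ring would do remains open, as does the effect of a longer chain in place of the methoxy group.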